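The source may hold more compounds than are shown below. What is called first, only, known or untested is meant among the compounds shown, and "the series" means these compounds.

Compound 1 `CCCCNc1nc(N)nc2c1CN(C(C)=O)CC2`: 0.5 uM
Compound 2 `CCCCNc1nc(N)nc2c1CCN(C(=O)c1ccccc1)C2`: 0.8 uM
Compound 3 `CCCCNc1nc(N)nc2c1CN(Cc1ccc(-c3ccccc3)cc1)CC2`: 0.5 uM

In an assay on HEK293 cells for agonist activity at Toll-like receptor 8 (Homo sapiens), read by a luciferase reporter, with a stated time of 6 h (on this read-out lower numbers stand for an effect already at smaller amounts and higher numbers for an effect only at larger amounts of compound), compound 1 gives 0.5 uM, the same number at the digits shown as compound 3 with 0.5 uM. Compound 2 gives 0.8 uM, a somewhat higher number, yet that gap still lies within the usual scatter, so none of the three can be set apart from the others.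

Compound 4 `CCCCNc1nc(N)nc2c1CN(Cc1ccncc1)CC2` is not yet measured. It differs from compound 1 in one place: (pyridin-4-yl)methyl in place of acetyl on an amine nitrogen in a ring. Compound 3 already carries a larger group on the same amine nitrogen and gives 0.5 uM, matching compound 1, so no step beyond the scatter is expected in this assay . Compound 4 is estimated at 0.5 uM, between 0.2 uM and 1.5 uM, which means an expected step of no change at the digits printed from compound 1 to compound 4 (within the scatter).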

Compound 4, minimum effective concentration: 0.29 uM
Compound 4: middle estimate off by 1.7-fold (0.24 log units), on the high side; the measured number falls inside the stated range.
By their numbers in this assay, from the lowest: compounds 4, 1, 3 and 2 (each within the scatter of the next, the first and the last beyond it).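

In this assay, replacing acetyl with (pyridin-4-yl)methyl on the amine nitrogen in the ring gives a 1.7-fold lower number from compound 1 to compound 4 (0.24 log units; within the scatter). This position therefore accepts a six-membered aromatic ring containing a hetero atom, with no step beyond the usual scatter, and the acetyl carbonyl is not needed to keep the number in this range. Nothing here accounts for how closely the two groups match. Still open, as far as these compounds go, is whether a carboxylic acid or a primary amine carried on this same nitrogen would stay in this range.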